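Adding a methyl to the phenyl ring: what to expect

This account rests on a few compounds, and the source may have more. Where it says the series, first, only, none or still open, it means among the compounds named here.

Three compounds have been measured in an assay for binding affinity to Adrenergic receptor alpha-1 (Rattus norvegicus); on this read-out lower numbers stand for stronger inhibition and higher numbers for weaker inhibition:

compound 1, `O=c1[nH]c2cc(-c3ccccc3)[nH]c2c(=O)n1CCN1CCN(c2ccccc2Cl)CC1`, gives 1.08 nM
compound 2, `COc1ccccc1N1CCN(CCCn2c(=O)[nH]c3cc(-c4ccccc4)[nH]c3c2=O)CC1`, gives 1.23 nM
compound 3, `Cc1ccc(-c2cc3[nH]c(=O)n(CCN4CCN(c5ccccc5Cl)CC4)c(=O)c3[nH]2)cc1`, gives 17.3 nM

Compound 1 and compound 3 differ in one place only, (methyl in place of hydrogen on an aromatic carbon). That single change produced a 16-fold higher number from compound 1 to compound 3 (1.20 log units; beyond the scatter), a clear weakening of binding. Compound 2 carries a different core from compound 1; how the two cores differ is not broken down here, but their numbers in this assay lie within the scatter of each other, so the two cores behave alike as far as these data show.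

Compound 4, `COc1ccccc1N1CCN(CCCn2c(=O)[nH]c3cc(-c4ccc(C)cc4)[nH]c3c2=O)CC1`, is the counterpart of compound 2 with the same change applied: methyl in place of hydrogen on an aromatic carbon. The place of the change is described in the same words for both pairs, so it is the same change on a closely related core. Among the compounds with values here, since the one measured example of this change, from compound 1 to compound 3, gave a 16-fold higher number from compound 1 to compound 3 (1.20 log units; beyond the scatter), a step of similar size is expected here, namely an 11-fold higher number from compound 2 to compound 4 (1.06 log units; beyond the scatter). Compound 4 is therefore estimated at 14 nM, most likely between 4 nM and 50 nM.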

Compound 4, inhibition constant: 47.9 nM
For compound 4 the middle estimate is 3.4-fold (0.53 log units) below the measured one; measured number inside the range.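

In this assay, replacing phenyl with 4-methylphenyl gave a 39-fold higher number from compound 2 to compound 4 (1.59 log units; beyond the scatter), so binding weakened on this core as it had on the core of compound 1. Set side by side, the two steps point the same way and do not differ measurably in size: the same change on two cores in this assay, a 16-fold higher number (1.20 log units; beyond the scatter) from compound 1 to compound 3 and a 39-fold higher number (1.59 log units; beyond the scatter) from compound 2 to compound 4, 2.4-fold (0.39 log units) apart, within the scatter of two such steps. On these two closely related cores, then, the effect of the methyl carried over from one to the other, but two pairs cannot show that it would hold on every core in the series, and they do not explain why binding weakens.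

The compounds shown leave open whether the loss is specific to methyl, since an ethyl group, a fluorine atom or a hydroxyl group in the same place, para to a large group, could give a smaller step, a larger one or none at all. From the compounds shown here alone, it also remains open whether a third core would respond to the methyl in the same way.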